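This account rests on a few compounds, and the source may have more. Where it says the series, first, only, none or still open, it means among the compounds named here.

Working notes on the cytotoxicity series.

Compound 1 `Cc1c(O)ccc2c1[C@H](Cn1cc(-c3ccccc3)nn1)[C@@]13CC(=O)[C@@](C)(CC[C@@H]21)C3` carries a free phenol on the aromatic ring of the shared core. In a functional assay on SMMC-7721 cells (Homo sapiens) for cytotoxicity, read by MTT assay, with a stated time of 4 days (a lower number here means a stronger inhibitor, a higher number a weaker inhibitor), compound 1 gives > 20000 nM, which is a limit of the assay and not a number. Compound 2 `Cc1ccc(S(=O)(=O)Oc2ccc3c(c2C)[C@H](Cn2cc(-c4ccccc4)nn2)[C@@]24CC(=O)[C@@](C)(CC[C@@H]32)C4)cc1` replaces that phenol hydrogen with a (4-methylphenyl)sulfonyl group. In this assay compound 2 gives > 20000 nM, again a limit rather than a number. The step that the two limits leave unreadable from compound 1 to compound 2 therefore cannot be read in either direction. Compound 3 `C=C1C[C@]23C[C@@]1(O)CC[C@@H]2c1cccc(C)c1[C@@H]3Cn1cc(-c2ccc(Cl)cc2)nn1`, with a different core and a chlorine on the aryl ring of the triazole, stands apart from this pair. In this assay compound 3 gives > 20000 nM, which is also a limit. The common picture is the limit of > 20000 nM in this assay, at which 3 of the 3 values shown sit.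

Compound 4 `Cc1ccc(-c2cn(C[C@H]3c4c(ccc(O)c4C)[C@@H]4CC[C@@]5(C)C[C@]43CC5=O)nn2)cc1` differs from compound 1 by methyl in place of hydrogen on an aromatic carbon. No measured step bears directly on this change; the only comparable step in the set, the phenol to sulfonate step, is unreadable because the limit of > 20000 nM in this assay, at which 3 of the 3 values shown sit, holds for every compound shown. With nothing in the series below the limit, compound 4 is expected to remain there as well, and the step that the limit leaves unreadable from compound 1 to compound 4 is estimated as no readable change. The estimate for compound 4 in this assay is 30000 nM, with a range from 10000 nM to 100000 nM.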

Compound 4, half-maximal inhibitory concentration: > 20000 nM
Compound 4: only a limit was reported; the forecaster's own chance of this, stated with the estimate: 85%; the middle value does not contradict the limit.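

Compound 4 gives > 20000 nM in this assay, which is a limit and not a number, so no step can be read between compound 1 and compound 4. The series shows one picture: the limit of > 20000 nM in this assay, at which 4 of the 4 values shown sit.

The compounds shown leave open how far any single change affects cytotoxicity, since none has a value inside the range of this assay.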